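A few compounds are considered here, and "the series" means these few. Any claim that something is new, unique, unknown or untested is made for them only; others in the source may bear on it.

Measured so far in an ADME assay on RAW264.7 cells (Mus musculus) for cytotoxicity, read by MTT assay, with a stated time of 48 h; a lower number here means a stronger inhibitor, a higher number a weaker inhibitor:
Compound 1 `Cc1cc(NC(=O)c2ccc(C#N)cc2)ccc1NS(=O)(=O)C(F)(F)F` gives 135000 nM.
Compound 2 `CCS(=O)(=O)Nc1ccc(NC(=O)c2ccc(Cl)cc2)cc1OC` gives 60100 nM.
Compound 3 `CCS(=O)(=O)Nc1ccc(NC(=O)c2ccc(C#N)cc2)cc1OC` gives 66400 nM.

Compound 3 stands close to compound 2: the step of a 1.1-fold higher number from compound 2 to compound 3 (0.04 log units; within the scatter) lies within the scatter, so the two cannot be told apart on these numbers. Compound 1 gives a higher number than compound 3, and that gap lies beyond the scatter.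

Compound 4 `COc1cc(NC(=O)c2ccc(C#N)cc2)ccc1NS(=O)(=O)C(F)(F)F` has not yet been measured in this assay. It differs from compound 3 by trifluoromethyl in place of ethyl on a sulfonyl sulfur. Among the measured compounds shown here, no measured step touches this change: the only step available, from compound 2 to compound 3, concerns the exchange of chloro for cyano elsewhere in the molecule and was within the scatter, so it says nothing about the sulfonyl group. The nearest hint comes from compound 1, which already carries a ((trifluoromethyl)sulfonyl)amino group next to the same nitrile-bearing amide and gives 135000 nM.

On that slender basis compound 4 is expected to give a somewhat higher number than compound 3, a step of about a 1.7-fold higher number from compound 3 to compound 4 (0.22 log units; within the scatter), which may not exceed the scatter. The estimate for compound 4 in this assay is 110000 nM, with a likely range from 50000 nM to 250000 nM.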

Compound 4, half-maximal inhibitory concentration: > 250000 nM
Compound 4: no number, only a limit (the forecaster's own chance of this, stated with the estimate: 15%); at least 2.2-fold (0.35 log units) between middle value and limit.
By their numbers in this assay, from the lowest: compounds 2 and 3 (each within the scatter of the next); then compound 1. At a limit, above all of these: compound 4.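

Compound 4 gives no number in this assay, only a limit of the assay: the limit of > 250000 nM in this assay, at which 1 of the 4 values shown sits.

Even so, trifluoromethyl in place of ethyl on a sulfonyl sulfur produces an at least 3.7-fold higher number from compound 3 to compound 4 (0.57 log units; beyond the scatter), the first measured change at this position, and it shows that this group can move the read-out clearly, whereas the earlier exchange of chloro for cyano elsewhere in the molecule stayed within the scatter. The other new comparison, methoxy in place of methyl on an aromatic carbon, gives an at least 1.8-fold higher number from compound 1 to compound 4 (0.26 log units; that floor lies within the scatter), so compound 1 and compound 4 cannot yet be separated with confidence, and these compounds show no clear effect of that exchange.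

The compounds shown carry only ethyl and trifluoromethyl on the sulfonyl sulfur, so it remains open how a methyl group, a longer chain such as propyl, or an amine would read at this position. With no true number for compound 4, the full size of both new steps stays unknown, and these data do not explain why the change at the sulfonyl sulfur has this effect.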